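A few compounds are considered here, and "the series" means these few. Any claim that something is new, unique, unknown or untested is made for them only; others in the source may bear on it.

Working notes on the series. Compound 1 `C=C(C)[C@@H]1CC=C(Cn2cc(COc3cccc(C4NC(=O)NC(C)=C4C(=O)OCC)c3)nn2)CC1` is the reference point; in an ADME assay on HaCaT cells (Homo sapiens) for inhibition, read by sulforhodamine B assay, with a stated time of 48 h (a higher number here means a weaker inhibitor of growth, a lower number a stronger inhibitor of growth), compound 1 gives 508000 nM. Compound 2 `C=C(C)[C@@H]1CC=C(Cn2cc(COc3cc(C4NC(=O)NC(C)=C4C(=O)OCC)ccc3OC)nn2)CC1` carries methoxy in place of hydrogen on an aromatic carbon. In this assay compound 2 gives 79800 nM. Among the measured compounds shown here, the single change produced a 6.4-fold lower number from compound 1 to compound 2 (0.80 log units; beyond the scatter).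

Compound 3 `C=C(C)[C@@H]1CC=C(Cn2cc(COc3ccc(C4NC(=O)NC5=C4C(=O)CC(C)(C)C5)cc3)nn2)CC1` has a different core; the difference between the two cores is not broken down here. In this assay compound 3 gives 436000 nM, which sits within the scatter of compound 1.

Compound 4 `C=C(C)[C@@H]1CC=C(Cn2cc(COc3ccc(C4NC(=O)NC5=C4C(=O)CC(C)(C)C5)cc3OC)nn2)CC1` is not yet measured and differs from compound 3 by methoxy in place of hydrogen on an aromatic carbon. For the measured compounds named here, this is the same kind of change as the one from compound 1 to compound 2, not the same: in compound 2 the methoxy is ortho to a large group and para to a large group, whereas in compound 4 it is ortho to a large group and meta to a large group.

Expectation: the step is estimated as a 4.0-fold lower number from compound 3 to compound 4 (0.60 log units; beyond the scatter), set beside a 6.4-fold lower number from compound 1 to compound 2 (0.80 log units; beyond the scatter); it rests on that single earlier step only, with the surroundings of the place differing. In this assay compound 4 is estimated at 110000 nM, expected to fall between 45000 nM and 300000 nM.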

Compound 4, concentration for total growth inhibition: 71300 nM
Compound 4: the middle estimate sits 1.5-fold (0.19 log units) above what was measured; the range from low to high includes it.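

In this assay methoxy in place of hydrogen on an aromatic carbon gives a 6.1-fold lower number from compound 3 to compound 4 (0.79 log units; beyond the scatter) on the core of compound 3, so the change carries over to this second core in this series. This rests on two pairs in a single assay and does not show that the step would hold on a further core, nor does it separate the contribution of the core from that of the place, which is ortho to a large group and meta to a large group in compound 4 but ortho to a large group and para to a large group in compound 2. The step on the core of compound 3 matches the one on the core of compound 1: the same change on two cores in this assay, a 6.4-fold lower number (0.80 log units; beyond the scatter) from compound 1 to compound 2 and a 6.1-fold lower number (0.79 log units; beyond the scatter) from compound 3 to compound 4, 1.0-fold (0.02 log units) apart, within the scatter of two such steps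

The compounds shown leave open whether a hydroxy, an ethoxy or a fluoro group in the same place would give a step of similar size. They also leave open whether an amine or a carboxylic acid there would carry over between the two cores in the same way.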